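A few compounds are considered here, and "the series" means these few. Any claim that something is new, unique, unknown or untested is made for them only; others in the source may bear on it.

The measured compounds in this study:

Compound 1, `CCN(CC)CCCCOc1c(OCc2ccccc2)cc2oc(-c3ccccc3)cc(=O)c2c1O`, gives 2200 nM.
Compound 2, `COc1cc2oc(-c3ccccc3)cc(=O)c2c(O)c1OCCCN1CCN(C)CC1`, gives 15100 nM.
Compound 3, `O=c1cc(-c2ccccc2)oc2cc(O)c(OCCCCN3CCCC3)c(O)c12`, gives only a limit, > 100000 nM.

All three were tested in a functional assay on HepG2 cells (Homo sapiens) for antiproliferative activity, read by MTT assay, with a stated time of 48 h; on this read-out higher numbers stand for weaker inhibition and lower numbers for stronger inhibition. Among the two numbers shown, compound 1 stands lowest, and the gap to the nearest, compound 2, is beyond the usual scatter, so compound 1 is the stronger of those two. For compound 3 the assay records no number: the limit of > 100000 nM in this assay, at which 1 of the 3 values shown sits.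

Compound 4, `CN1CCN(CCCCOc2c(OCc3ccccc3)cc3oc(-c4ccccc4)cc(=O)c3c2O)CC1`, has not yet been measured in this assay. It differs from compound 1 in one place: 4-methylpiperazin-1-yl in place of diethylamino on a saturated chain carbon, four bonds along the chain from an oxygen on an aromatic ring.

Going by the values given here, no pair of measured compounds differing in one place is available, so the size of this step cannot be read from a comparable change. Compound 2, which carries the entering group on a different chain and a different core, gives a higher number than compound 1, but the two differ in more than one place, so that comparison carries limited weight. The step is expected to be a modest weakening, a 2.3-fold higher number from compound 1 to compound 4 (0.36 log units; beyond the scatter), at or a little beyond the scatter. Compound 4 is estimated at 5000 nM, with a range from 1500 nM to 16000 nM.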

Compound 4, half-maximal inhibitory concentration: 2500 nM
Beside the measured number, compound 4's estimate is 2.0-fold (0.30 log units) above it, and the stated range covers the measured number.
By their numbers in this assay, from the lowest: compounds 1 and 4 (each within the scatter of the next); then compound 2. At a limit, above all of these: compound 3.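

In this assay, 4-methylpiperazin-1-yl in place of diethylamino on a saturated chain carbon, four bonds along the chain from an oxygen on an aromatic ring, gives a 1.1-fold higher number from compound 1 to compound 4 (0.06 log units; within the scatter), so at this place the two amines cannot be told apart by their numbers. Going by these compounds alone, this is the first comparison in the set that changes one place only, and it shows that the entering six-membered non-aromatic ring, with its 2 hetero atoms, leaves the antiproliferative reading of this chain and core within the scatter, which the earlier compounds, differing in more than one place, could not show. Nothing measured here bears on why the step is so small.

The compounds shown leave open whether a morpholine, a piperidine or a primary amine at the same place would read alike, and whether a longer chain carrying either amine would keep the two together. They also leave open whether the same exchange would stay this small on the core of compound 2 or of compound 3, where a free hydroxyl or a methoxy group stands in place of the benzyl ether.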